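The source may report more compounds than this note shows. Statements on the series, on what has been measured and on what is new or still open speak of the compounds shown alone.

Compound 1 `O=C(CSc1nnc(-c2ccncc2)o1)N/N=C/c1ccccc1` carries a phenyl on a carbon with a double bond to nitrogen. Among the measured compounds shown here, in a functional assay on SW 1116 cells (Homo sapiens) for cytotoxicity, read by MTT assay, with a stated time of 48 h (a higher number here means a weaker inhibitor, a lower number a stronger inhibitor), compound 1 gives 16700 nM, the second highest of the three numbers measured so far. Compound 2 `Cc1ccc(/C=N/NC(=O)CSc2nnc(-c3ccncc3)o2)cc1` gives 16800 nM, and a 1.0-fold higher number from compound 1 to compound 2 (0.00 log units; within the scatter). Compound 3 `O=C(CSc1nnc(-c2ccncc2)o1)N/N=C/c1cc(Br)ccc1O` gives 8150 nM, so that a 2.0-fold lower number from compound 1 to compound 3 (0.31 log units; beyond the scatter). Compound 4 `O=C(CSc1nnc(-c2ccncc2)o1)N/N=C/c1cc(Cl)cc(Cl)c1O` has not yet been measured; its change from compound 1 is 3,5-dichloro-2-hydroxyphenyl in place of phenyl on a carbon with a double bond to nitrogen. For the measured compounds named here, the closest precedent is the step to compound 3, where a 2.0-fold lower number from compound 1 to compound 3 (0.31 log units; beyond the scatter); the step of a 2.1-fold lower number from compound 2 to compound 3 (0.31 log units; beyond the scatter) has the same size. A modest drop of similar size is therefore expected in this assay for compound 4. The estimate for compound 4 is 7500 nM, within 4000 nM to 16000 nM, an expected step of a 2.2-fold lower number from compound 1 to compound 4 (0.35 log units; beyond the scatter).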

Compound 4, half-maximal inhibitory concentration: 5030 nM
The estimate for compound 4 lay 1.5-fold (0.17 log units) above the measured number; measured number inside the range.
By their numbers in this assay, from the lowest: compounds 4 and 3 (each within the scatter of the next); then compounds 1 and 2 (each within the scatter of the next).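

In this assay, placing 3,5-dichloro-2-hydroxyphenyl on the carbon with a double bond to nitrogen gives a step beyond the scatter from either earlier reference, a 3.3-fold lower number from compound 1 to compound 4 (0.52 log units; beyond the scatter) and a 3.3-fold lower number from compound 2 to compound 4 (0.52 log units; beyond the scatter). The change of halogen pattern within the hydroxyphenyl series does not separate the two compounds, with a 1.6-fold lower number from compound 3 to compound 4 (0.21 log units; within the scatter). No measurement given here bears on why these groups behave this way. The compounds shown leave open whether the hydroxyl or the halogens carry the step, since neither a 2-hydroxyphenyl without halogen nor a chlorophenyl without hydroxyl stands among them. Going by these compounds, how an amine or a carboxylic acid on this ring would read also remains open.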